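The source may report more compounds than this note shows. Statements on the series, on what has been measured and on what is new or still open speak of the compounds shown alone.

Compound 3 `CCOc1ccc(NC(=O)Nc2ccc(OC[C@@]3(C)Cn4cc([N+](=O)[O-])nc4O3)cc2)cc1` is a diaryl urea of the shared core carrying an ethoxy group. In a physicochemical assay for solubility, read by HPLC, with a stated time of 4 h, at pH 7 (on this read-out lower numbers stand for lower solubility and higher numbers for higher solubility), compound 3 gives 6.66 ug/mL, the lower of the two numbers seen so far. Its nearest neighbour is the thiourea compound 2 `COc1ccc(NC(=S)Nc2ccc(OC[C@@]3(C)Cn4cc([N+](=O)[O-])nc4O3)cc2)cc1`, which in this assay gives 8.66 ug/mL, within the scatter of compound 3. The trifluoromethyl analogue compound 1 `C[C@]1(COc2ccc(NC(=O)Nc3ccc(C(F)(F)F)cc3)cc2)Cn2cc([N+](=O)[O-])nc2O1` in this assay gives < 1 ug/mL, which is a limit of the assay rather than a number (the limit of < 1 ug/mL in this assay, at which 1 of the 3 values shown sits). Among the measured compounds shown here, the one step measured in one place, ethoxy in place of trifluoromethyl on an aromatic carbon, gives an at least 6.6-fold higher number from compound 1 to compound 3 (0.82 log units; beyond the scatter).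

The next compound, compound 4 `C[C@]1(COc2ccc(NC(=O)Nc3ccc(Cl)cc3)cc2)Cn2cc([N+](=O)[O-])nc2O1`, differs from compound 3 in one place: chloro in place of ethoxy on an aromatic carbon. For the measured compounds named here, this is the only bearing step available: trading the ethoxy for a halogen runs in the reverse sense to the step that carried compound 1 to compound 3, so a move back toward the limit is expected, in the same direction and of roughly comparable size, though a single halogen need not match trifluoromethyl. The expected step is a 4.4-fold lower number from compound 3 to compound 4 (0.65 log units; beyond the scatter). Compound 4 is therefore estimated at 1.5 ug/mL, with a range from 0.5 ug/mL to 4 ug/mL, and a fair chance that the assay returns only a limit.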

Compound 4, solubility: 6.66 ug/mL
Beside the measured number, compound 4's estimate is 4.4-fold (0.65 log units) below it; the measured number lies above the stated range.
By their numbers in this assay, from the lowest: compounds 3, 4 and 2 (each within the scatter of the next). At a limit, below all of these: compound 1.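

In this assay, chloro in place of ethoxy on the aromatic carbon para to a large group gives no change at the digits printed from compound 3 to compound 4 (within the scatter), so removing the ethoxy does not by itself reverse the earlier step. Chloro in place of trifluoromethyl gives an at least 6.6-fold higher number from compound 1 to compound 4 (0.82 log units; beyond the scatter), which shows that among compounds 1, 3 and 4 only the trifluoromethyl compound stands apart, while ethoxy and chloro read alike despite differing in heavy atoms and hydrogen-bond acceptors. Compound 1 remains a limit and not a number, so both steps from it are bounds rather than sizes: the limit of < 1 ug/mL in this assay, at which 1 of the 4 values shown sits.

From the compounds shown here alone, whether the flat reading between compound 3 and compound 4 extends to other groups at this position, such as an amine, a carboxylic acid or a longer alkoxy chain, remains open. Compound 2 differs from compound 3 in more than one place, so the compounds shown do not separate the exchange of urea for thiourea from the exchange of ethoxy for methoxy.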